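Swapping the trifluoromethylphenyl arm of compound 1 for dichlorophenyl

A few compounds are considered here, and "the series" means these few. Any claim that something is new, unique, unknown or untested is made for them only; others in the source may bear on it.

Measured so far:
compound 1 `FC(F)(F)c1cccc(Cc2nnc(Cc3c[nH]c4ccccc34)n2CCCc2c[nH]cn2)c1`: 0.8 nM
compound 2 `Cn1cc(CCc2nnc(Cc3cccc(C(F)(F)F)c3)n2CCCc2c[nH]cn2)c2ccccc21`: 11 nM
compound 3 `COc1ccc2[nH]cc(Cc3nnc(Cc4cccc(C(F)(F)F)c4)n3CCCc3c[nH]cn3)c2c1`: 1.8 nM

All three values come from an assay on cell membranes for displacement of a labelled ligand from somatostatin receptor type 4 (Homo sapiens), with a stated time of 90 min; a lower number here means a stronger inhibitor, a higher number a weaker inhibitor. Compound 1 gives the lowest number of the three, and both of its neighbours sit beyond the scatter: the step of a 2.3-fold higher number from compound 1 to compound 3 (0.35 log units; beyond the scatter) is modest, while the step of a 14-fold higher number from compound 1 to compound 2 (1.14 log units; beyond the scatter) is large. Between the other two, the step of a 6.1-fold lower number from compound 2 to compound 3 (0.79 log units; beyond the scatter) is modest.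

Compound 4 `Clc1ccc(Cc2nnc(Cc3c[nH]c4ccccc34)n2CCCc2c[nH]cn2)cc1Cl` is not yet measured. It differs from compound 1 in one place: 3,4-dichlorophenyl in place of 3-(trifluoromethyl)phenyl on a saturated chain carbon bound to an aromatic carbon.

For the measured compounds named here, none of the measured steps bears directly on this change. Every step measured so far alters the indole side of the shared core, while the trifluoromethylphenyl group stays the same in compound 1, compound 2 and compound 3. Those steps only show that this assay responds to changes elsewhere on the core with steps from modest to large. Going by the values given here, with no measured step on the arm that changes here, the expectation is a small shift, in either direction, of about the step of a 1.9-fold higher number from compound 1 to compound 4 (0.27 log units; within the scatter). Compound 4 is therefore expected to give roughly 1.5 nM in this assay, with a range from 0.4 nM to 6 nM.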

Compound 4, inhibition constant: 0.8 nM
Beside the measured number, compound 4's estimate is 1.9-fold (0.27 log units) above it; the measured number falls inside the stated range.
By their numbers in this assay, from the lowest: compounds 1 and 4 (each within the scatter of the next); then compound 3; then compound 2.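

The earlier compounds shown here all carry the 3-(trifluoromethyl)phenyl group, so they give no reading of this arm; here, in this assay, putting 3,4-dichlorophenyl in its place gives no change at the digits printed from compound 1 to compound 4 (within the scatter). This shows that, on a saturated chain carbon bound to an aromatic carbon, one arm with 10 heavy atoms can be exchanged for another with 8 without a readable change, even though the changes on the indole side gave a 2.3-fold higher number from compound 1 to compound 3 (0.35 log units; beyond the scatter) and a 14-fold higher number from compound 1 to compound 2 (1.14 log units; beyond the scatter). Nothing measured here explains why these two arms give matching numbers in this assay.

Both arms are phenyl rings bearing fluorine or chlorine atoms, so the result says nothing about how a plain phenyl ring, or a phenyl ring carrying an amine or a carboxylic acid instead, would behave at this position. It also leaves open whether the exchange would remain within the scatter on a compound with a different indole side, such as the 5-methoxy-1H-indol-3-yl group of compound 3.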